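Hydroxy on the Amino Nitrogen of Compound 1

The source may report more compounds than this note shows. Statements on the series, on what has been measured and on what is new or still open speak of the compounds shown alone.

Compound 1, `Nc1cc(=O)[nH]c(=O)n1[C@@H]1O[C@H](CO)[C@@H](O)[C@H]1O`: > 50000 nM in a functional assay on SKW3 cells (Homo sapiens) for antiproliferative activity, read by WST assay, with a stated time of 3 days; a higher number here means a weaker inhibitor, a lower number a stronger inhibitor
Compound 2, `CNc1cc(=O)[nH]c(=O)n1[C@@H]1O[C@H](CO)[C@@H](O)[C@H]1O`: > 50000 nM in this assay
Compound 3, `CN(C)c1cc(=O)[nH]c(=O)n1[C@@H]1O[C@H](CO)[C@@H](O)[C@H]1O`: > 50000 nM in this assay

Compound 1 stands at the limit of this assay; its value is a limit, not a measured number. The same holds for compound 2 and for compound 3, as the limit of > 50000 nM in this assay, at which 3 of the 3 values shown sit, records. The steps from compound 1 onward are therefore unreadable: a step that the two limits leave unreadable from compound 1 to compound 2, a step that the two limits leave unreadable from compound 1 to compound 3 and a step that the two limits leave unreadable from compound 2 to compound 3 all lie between two limits, so none gives a size or a direction.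

Compound 4, `O=c1cc(NO)n([C@@H]2O[C@H](CO)[C@@H](O)[C@H]2O)c(=O)[nH]1`, differs from compound 1 by hydroxy in place of hydrogen on a nitrogen on an aromatic ring. Among the measured compounds shown here, no measured step bears on this change in a readable way, and every value in this assay so far sits at the limit. The expectation for compound 4 is accordingly a step that the limit leaves unreadable from compound 1 to compound 4, which is to say no step beyond the scatter and a value again at the limit. The estimate for compound 4 in this assay is 70000 nM, within a range from 25000 nM to 200000 nM, with a strong chance that only a limit is reported.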

Compound 4, half-maximal inhibitory concentration: > 50000 nM
Compound 4 ended at the assay's limit (the forecaster's own chance of this, stated with the estimate: 85%); the middle value does not contradict the limit.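

Compound 4 gives only a limit in this assay, as do compound 1, compound 2 and compound 3, so no step to compound 4 can be read: the limit of > 50000 nM in this assay, at which 4 of the 4 values shown sit.

The compounds shown leave open whether any change on this amino nitrogen gives a measurable value in this assay.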